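Moving the hydroxyl: compound 3 to compound 4

The source may hold more compounds than are shown below. What is called first, only, known or untested is meant among the compounds shown, and "the series" means these compounds.

In a functional assay on RAW264.7 cells (Mus musculus) for inhibition, read by fluorescence, with stated times of 1 h, 24 h and 30 min (a higher number here means a weaker inhibitor, a lower number a stronger inhibitor), compound 1 `O=C(/C=C/c1cccc(F)c1)c1ccccc1O` gives > 10000 nM, which is a limit of the assay and not a number. Compound 2 `O=C(/C=C/c1cccc(F)c1)c1ccc(O)cc1` gives 9150 nM. Compound 3 `O=C(/C=C/c1cccc(C(F)(F)F)c1)c1ccccc1O` has no number to stand on, its entry reading "not determined" (no result reported). Compound 4 `O=C(/C=C/c1cccc(C(F)(F)F)c1)c1ccc(O)cc1` is still to be measured. The change 4-hydroxyphenyl in place of 2-hydroxyphenyl on a carbonyl carbon puts 4-hydroxyphenyl in place of 2-hydroxyphenyl on a carbonyl carbon. Going by the values given here, no measured step exists, so the size is a judgement. A modest move towards stronger inhibition in this assay is expected because compound 2 with its 4-hydroxyphenyl reads 9150 nM. For compound 4 the estimated value is 6000 nM, with an expected range of 2000 nM to 12000 nM.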

Compound 4, half-maximal inhibitory concentration: 1440 nM
Estimate against measurement, compound 4: 4.2-fold (0.62 log units) above; the whole stated range lies above it.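

In this assay, going by these compounds alone, with 4-hydroxyphenyl held on the carbonyl carbon, trifluoromethyl in place of fluoro gives a 6.4-fold lower number from compound 2 to compound 4 (0.80 log units; beyond the scatter), the first readable step and evidence that this aromatic substituent affects the read-out. The hydroxyl move from compound 3 to compound 4 cannot be read, as compound 3 has no result. Compound 1 gives a limit and not a number, so its comparison with compound 2 yields no step size: the limit of > 10000 nM in this assay, at which 1 of the 4 values shown sits.

Still open, as far as these compounds go, is whether a nitrile or an amine in place of trifluoromethyl would give a similar value. Also open, from the compounds shown here alone, is whether a carboxylic acid in place of the hydroxyl would keep the inhibition of compound 4.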